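The source may report more compounds than this note shows. Statements on the series, on what has been measured and on what is new or still open speak of the compounds shown alone.

Compound 2 `Nc1cccc(-c2cn3nc(Cc4ccccc4)sc3n2)c1` carries a benzyl group on the shared core. In a functional assay on CCRF-CEM cells (Homo sapiens) for inhibition, read by cell counting, with a stated time of 3 days (on this read-out lower numbers stand for stronger inhibition and higher numbers for weaker inhibition), compound 2 gives 37000 nM, the highest of the three numbers measured here. Compound 3 `Nc1cccc(-c2cn3nc(-c4ccccc4)sc3n2)c1` gives 33000 nM in this assay, and compound 1 `C=C(Br)C(=O)Nc1cccc(-c2cn3nc(CCc4ccccc4)sc3n2)c1`, which carries a different substituent on the aniline nitrogen, gives 4200 nM there.

The step to compound 4 `Nc1cccc(-c2cn3nc(CCc4ccccc4)sc3n2)c1` is a change at the chain on the core: benzyl in place of phenyl on a saturated chain carbon bound to an aromatic carbon. Within the data shown here, only one measured step speaks to this kind of change. Going from compound 2 to compound 3 the benzyl was shortened to a phenyl, and this gave a 1.1-fold lower number from compound 2 to compound 3 (0.05 log units; within the scatter), a change that did not leave the usual scatter. Lengthening the chain by one carbon, the change from compound 2 to compound 4, is expected to behave alike, so the expected step of no change at the digits printed from compound 2 to compound 4 (within the scatter) lies within the scatter.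

Compound 4 is therefore estimated at 37000 nM in this assay, with a plausible range from 15000 nM to 90000 nM.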

Compound 4, half-maximal inhibitory concentration: 30000 nM
Compound 4: the middle estimate sits 1.2-fold (0.09 log units) above what was measured; low and high end bracket the measured number.
By their numbers in this assay, from the lowest: compound 1; then compounds 4, 3 and 2 (each within the scatter of the next).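

In this assay, the step of a 1.2-fold lower number from compound 2 to compound 4 (0.09 log units; within the scatter) shows that the chain on the core can also grow by one carbon without a readable effect, so compounds 2, 3 and 4, which all carry a bare amine on the aniline nitrogen, stay within the scatter across these chain lengths. Among these compounds, compound 4 also supplies the first pair that differs only at that nitrogen: a 7.1-fold higher number from compound 1 to compound 4 (0.85 log units; beyond the scatter), a modest step beyond the scatter, which places the larger difference at the nitrogen, not the chain. Nothing shown gives a cause for either step.

Going by these compounds, it remains open whether chain length would matter in compounds that keep the (1-bromoethenyl)carbonyl group. On these data alone, it is also open whether a plain acetyl on the nitrogen, or a longer chain on the core, would shift the number.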